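A few compounds are considered here, and "the series" means these few. Any claim that something is new, unique, unknown or untested is made for them only; others in the source may bear on it.

Compound 1 `Cc1ccccc1Nc1nc(NC2CC2)ncc1Cl` is tested in a functional assay on MDA-MB-231 cells (Homo sapiens) for inhibition, read by CCK-8 assay, with a stated time of 48 h (a lower number here means a stronger inhibitor of growth, a higher number a weaker inhibitor of growth), where it gives > 100000 nM, which is a limit of the assay rather than a number. Compound 2 `CCN1CCN(c2ccc(Nc3ncc(Cl)c(Nc4ccccc4C)n3)nc2)CC1` likewise gives > 100000 nM in this assay, again a limit. Compound 3 `COc1ccccc1CNc1nc(Nc2ccc(N3CCN(C)CC3)cn2)ncc1Cl` is the only one of the three with an actual number, giving 29300 nM in this assay. Compounds 1 and 2 both sit at the limit of > 100000 nM in this assay, at which 2 of the 3 values shown sit.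

Compound 4 `COc1cccc(Nc2nc(Nc3ccc(N4CCN(C)CC4)cn3)ncc2Cl)c1` has not yet been measured. It differs from compound 3 by 3-methoxyphenyl in place of 2-methoxybenzyl on a nitrogen on an aromatic ring. Going by the values given here, no measured pair isolates this change, so the step is uncertain. The expected step of a 1.4-fold higher number from compound 3 to compound 4 (0.14 log units; within the scatter) is small, toward weaker inhibition, and may well stay within the scatter. Compound 4 is therefore estimated at 40000 nM, with a likely range from 10000 nM to 100000 nM.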

Compound 4, concentration for 50% growth inhibition: 8510 nM
Beside the measured number, compound 4's estimate is 4.7-fold (0.67 log units) above it; measured number below the stated range.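

In this assay, going by these compounds alone, the change on this nitrogen gives a 3.4-fold lower number from compound 3 to compound 4 (0.54 log units; beyond the scatter) and is the first measured step here, showing that growth inhibition responds to the group held at this place. Compounds 1 and 2 remain at a limit rather than a number: the limit of > 100000 nM in this assay, at which 2 of the 4 values shown sit.

This single swap both removes the benzyl carbon and moves the methoxy group, so the step cannot be assigned to either alone. On these data alone, whether a 2-methoxyphenyl or a 3-methoxybenzyl group would match compound 3 or compound 4 remains open.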